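Swapping 4-chlorophenyl for 5-nitrothiophen-3-yl

This account rests on a few compounds, and the source may have more. Where it says the series, first, only, none or still open, it means among the compounds named here.

Three related compounds have been tested so far. In a functional assay on Caco-2 cells (Homo sapiens) for inhibition, read by MTT assay, with a stated time of 48 h, tested at 10 uM (a higher number here means more inhibition of growth at the concentration tested, a lower number less inhibition of growth), compound 1 (`Cc1cc(=O)c2c(O)cc(OCc3ccc([N+](=O)[O-])cc3)c([C@H]3CCN(C)C[C@H]3O)c2o1`) reaches 14% and compound 2 (`Cc1cc(=O)c2c(O)c(CN3CCCCC3)c(O)c([C@H]3CCN(C)C[C@H]3O)c2o1`) reaches 22% while compound 3 (`Cc1oc2c([C@H]3CCN(C)C[C@H]3O)c(O)cc(O)c2c(=O)c1C(O)c1ccc(Cl)cc1`) reaches only 3% in the same test. That makes compound 3 the lowest of the three, and its gaps to both of the others lie beyond the usual scatter of repeated measurements.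

Compound 4 (`Cc1oc2c([C@H]3CCN(C)C[C@H]3O)c(O)cc(O)c2c(=O)c1C(O)c1csc([N+](=O)[O-])c1`) has not been measured yet. It carries 5-nitrothiophen-3-yl in place of 4-chlorophenyl on a saturated chain carbon bound to an aromatic carbon and an oxygen on a saturated carbon. Going by the values given here, no two measured compounds differ in only one place, so the data show no direct precedent for this swap. Only a loose frame remains: even compound 2 stops at 22% on this scale, so a large jump seems unlikely. With compound 3 at 3% there is little room left to fall, so any shift is more likely upward. In this assay the expected step is a number 7 percentage points higher from compound 3 to compound 4 (within the scatter) and this estimated small rise would stay within the scatter. Compound 4 is expected at 10% with an estimated range from 0% to 25% around that figure.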

Compound 4, percent growth inhibition at one concentration: 3%
Compound 4: the middle estimate sits 7 percentage points above what was measured, and the stated range covers the measured number.
By their numbers in this assay, from the lowest: compounds 3 and 4 (each within the scatter of the next); then compounds 1 and 2 (each within the scatter of the next).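

In this assay, going by these compounds alone, putting 5-nitrothiophen-3-yl in place of 4-chlorophenyl on the saturated chain carbon gives no change at the digits printed from compound 3 to compound 4 (within the scatter), the first comparison in this set in which only one place differs. At this position, a six-membered aromatic ring of carbon only can thus give way to a five-membered aromatic ring with a hetero atom, and hydrogen-bond acceptors can enter where there were none, with no detectable effect on the number, although a number this low leaves little room to show a further fall. No measurement at hand offers an explanation for this result.

As far as these compounds go, what an amine or a carboxylic acid would do in place of the aromatic ring on this carbon stays open, as does the effect of a longer chain carrying that ring. The hydroxy group on the same carbon is present in both compounds, so its contribution is also unknown, and a methoxy group there would be one way to probe it.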